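Removing an octyl chain: expected cytotoxicity of compound 4

This account rests on a few compounds, and the source may have more. Where it says the series, first, only, none or still open, it means among the compounds named here.

Measured compounds:
compound 1 `Cc1cc(O)c(C(=O)NCCCc2ccccc2)c(=O)o1` gives 143000 nM
compound 2 `Cc1cc(O)c(C(=S)Nc2ccccc2)c(=O)o1` gives > 200000 nM
compound 3 `CCCCCCCCCCCCCCCC(=O)c1c(O)cc(C)oc1=O` gives 165000 nM

In an ADME assay on L929 cells (Mus musculus, culture collection number NCTC 929) for cytotoxicity, read by MTT assay, with a stated time of 72 h (a lower number here means a stronger inhibitor, a higher number a weaker inhibitor), compound 3 stands at the highest of the two numbers shown, yet compound 1 with 143000 nM lies within the usual scatter of it, so the two cannot be told apart. For compound 2 the result > 200000 nM is a limit of the assay, not a number. Compound 4 `CCCCCCCC(=O)c1c(O)cc(C)oc1=O` differs from compound 3 in one place: hydrogen in place of octyl on a saturated chain carbon, seven bonds along the chain from a carbonyl carbon. Going by the values given here, no step of this kind has been measured here. Since all three results sit near the top of the range, the step from compound 3 to compound 4 is expected to be small, a 1.1-fold higher number from compound 3 to compound 4 (0.04 log units; within the scatter), in the direction of an equal or weaker inhibitor. Compound 4 is therefore expected to give 180000 nM, between 100000 nM and 320000 nM.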

Compound 4, half-maximal inhibitory concentration: 140000 nM
The estimate for compound 4 lay 1.3-fold (0.11 log units) above the measured number, and the stated range covers the measured number.
By their numbers in this assay, from the lowest: compounds 4, 1 and 3 (each within the scatter of the next). At a limit, above all of these: compound 2.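

Going by these compounds alone, replacing octyl with hydrogen at this position, on a saturated chain carbon, seven bonds along the chain from a carbonyl carbon, gives the first step that can be read in this assay: a 1.2-fold lower number from compound 3 to compound 4 (0.07 log units; within the scatter). Those 8 carbon atoms can therefore go without a difference that this assay can tell from scatter. Nothing shown bears on why the chain's length leaves the number in place. On these data alone, a much shorter chain, or a chain ending in an amine or a carboxylic acid, remains open. So does a chain longer than that of compound 3.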